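Swapping the aryl group on an aromatic nitrogen

A few compounds are considered here, and "the series" means these few. Any claim that something is new, unique, unknown or untested is made for them only; others in the source may bear on it.

Of the compounds shown here, two built on a shared core have been measured in a functional assay on HCT-116 cells (Homo sapiens) for antiproliferative activity, read by MTT assay, with a stated time of 48 h; a lower number here means a stronger inhibitor, a higher number a weaker inhibitor. Compound 1 `N#CC1=C(N)Oc2c(c3nc4ccccc4nc3c3ccccc23)C12C(=O)N(Cc1cnnn1-c1ccc(S(N)(=O)=O)cc1)c1ccccc12` gives 31200 nM. Compound 2 `CCc1ccccc1-n1nncc1CN1C(=O)C2(C(C#N)=C(N)Oc3c(N)cc4nc5ccccc5nc4c32)c2ccccc21` gives 10300 nM, the lowest of the two numbers, and its distance from compound 1 lies beyond the usual scatter of this assay. For the measured compounds named here, no step between measured compounds that differ in a single place is available, so the weight of any one change remains open.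

Compound 3 `CC(=O)Nc1ccc(-n2nncc2CN2C(=O)C3(C(C#N)=C(N)Oc4c(N)cc5nc6ccccc6nc5c43)c3ccccc32)cc1` differs from compound 2 in one place: 4-acetamidophenyl in place of 2-ethylphenyl on an aromatic nitrogen. In words, 4-acetamidophenyl takes the place of 2-ethylphenyl on an aromatic nitrogen of a five-membered aromatic ring with 3 nitrogen.

Without a single-place step to lean on, the expected step is judged to be small, either toward a somewhat higher number or none beyond the scatter, which is what a 1.3-fold higher number from compound 2 to compound 3 (0.10 log units; within the scatter) expresses. Compound 3 is accordingly estimated at 13000 nM, with a range expected to run from 4000 nM to 40000 nM.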

Compound 3, half-maximal inhibitory concentration: > 50000 nM
Compound 3: no number, only a limit; the forecaster's own chance of this, stated with the estimate: 10%; middle value at least 3.8-fold (0.58 log units) from the limit.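

On this aromatic nitrogen the aryl group proves not to be freely exchangeable: in this assay, 4-acetamidophenyl in place of 2-ethylphenyl comes with an at least 4.8-fold higher number from compound 2 to compound 3 (0.68 log units; beyond the scatter), the only single-place step shown in this series and one that lies beyond the scatter. Compound 3 stands at > 50000 nM, which is a limit of the assay and not a number. The change therefore fixes only a lower bound on the size of the step, and its full size cannot be read: the limit of > 50000 nM in this assay, at which 1 of the 3 values shown sits.

The step alone does not separate the effect of exchanging ethyl for acetamido from the effect of the substituent's place on the phenyl ring, as the two groups differ in both respects at once. How a 4-ethylphenyl group, a 2-acetamidophenyl group or a phenyl ring carrying a simple amine would read on this nitrogen stands open, and so does whether the same exchange would give a similar step on a core other than that of compound 2.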